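Swapping an oxadiazole for a methoxime on the aniline core

The compounds below may be only part of what the source reports. "The series", "measured", "known", "first", "only" and "open" are said of these compounds alone.

Among the measured compounds shown here, compound 1 `Cc1nc(-c2ccccc2NCC2=NCCN2)no1` is the only member of this small set with a full number in a functional assay for activation of Alpha-1B adrenergic receptor (Homo sapiens), read by calcium flux (on this read-out higher numbers stand for an effect only at larger amounts of compound and lower numbers for an effect already at smaller amounts), where compound 1 gives 676 nM. Compound 2 `Cc1cccnc1-c1ccccc1NCC1=NCCN1` reaches only a limit of this assay, < 100000 nM. Compound 3 `Nc1nccc(-c2ccccc2NCC2=NCCN2)n1` likewise stops at a limit, < 5020 nM. Compound 4 `CO/N=C/c1ccccc1NCC1=NCCN1` carries a group of 4 heavy atoms (2 carbon, 1 nitrogen, 1 oxygen; no ring) in place of a group of 6 heavy atoms (3 carbon, 2 nitrogen, 1 oxygen; one five-membered aromatic ring with 3 hetero atoms), on an aromatic carbon, so that a group of 4 heavy atoms (2 carbon, 1 nitrogen, 1 oxygen; no ring) stands in place of a group of 6 heavy atoms (3 carbon, 2 nitrogen, 1 oxygen; one five-membered aromatic ring with 3 hetero atoms), on an aromatic carbon. For the measured compounds named here, no measured pair shows this change, so the expected step of a 2.2-fold higher number from compound 1 to compound 4 (0.35 log units; beyond the scatter) is a modest loss, just beyond the scatter. For compound 4 the estimate is 1500 nM, between 300 nM and 8000 nM.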

Compound 4, half-maximal effective concentration: < 5020 nM
Compound 4: no number, only a limit (the forecaster's own chance of this, stated with the estimate: 25%); the middle value lies beyond the limit too.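

Compound 4 reaches only a limit in this assay, so its step from compound 1 cannot be read: the limit of < 5020 nM in this assay, at which 2 of the 4 values shown sit.

On these data alone, what replacing the 5-methyl-1,2,4-oxadiazol-3-yl group does to the read-out, in direction and in size, stays open across compound 1 and compound 4.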